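Phenyl for trifluoromethyl: compound 3 to compound 4

The source may report more compounds than this note shows. Statements on the series, on what has been measured and on what is new or still open speak of the compounds shown alone.

Measured so far, all in an assay for inhibition of inositol hexakisphosphate kinase 2 (Homo sapiens), read by colorimetric assay, coupled enzyme assay and malachite green, with a stated time of 120 min, in the presence of a further agent that is not named here; on this read-out lower numbers stand for stronger inhibition and higher numbers for weaker inhibition:
compound 1, `Cc1cccc(-c2onc3ccc(/C=C/C(=O)O)cc23)c1`, gives 290 nM
compound 2, `O=C(O)c1ccc2noc(-c3ccc(Oc4ccccn4)cc3)c2c1`, gives 1190 nM
compound 3, `O=C(O)c1ccc2noc(-c3cccc(C(F)(F)F)c3)c2c1`, gives 1460 nM

Compound 3 carries the highest of the three numbers. Against compound 2 its value sits within the usual scatter, so the two cannot be ordered. Against compound 1 the gap lies beyond the scatter, and compound 1 holds the lower number; compound 1 differs from compound 3 in more than one place, so no single step can be read from that pair.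

Compound 4, `O=C(O)c1ccc2noc(-c3cccc(-c4ccccc4)c3)c2c1`, is not yet measured. It differs from compound 3 in one place: phenyl in place of trifluoromethyl on an aromatic carbon, on an aromatic carbon of a six-membered aromatic ring of carbon only, meta to a large group.

Among the compounds with values here, no pair of measured compounds differing in one place exists in this set, so the size of a single-change step is unknown here. Within the data shown here, the only guide is that compound 1, which also carries a substituted aromatic ring at the same end of the shared core, gives 290 nM. A step from compound 3 toward a somewhat lower number is expected, a 1.6-fold lower number from compound 3 to compound 4 (0.21 log units; within the scatter), though it may stay within the scatter.

Compound 4 is estimated at 900 nM in this assay, with a range from 300 nM to 2700 nM.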

Compound 4, half-maximal inhibitory concentration: 130 nM
Estimate against measurement, compound 4: 6.9-fold (0.84 log units) above, outside the stated range (below it).
By their numbers in this assay, from the lowest: compound 4; then compound 1; then compounds 2 and 3 (each within the scatter of the next).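

In this assay, within the data shown here, the aromatic carbon that carries trifluoromethyl in compound 3 proves responsive to a change of substituent: an 11-fold lower number from compound 3 to compound 4 (1.05 log units; beyond the scatter), the first single-place step that can be read. The exchange replaces a group of 4 heavy atoms and no ring with phenyl, which has 6 heavy atoms and one six-membered aromatic ring of carbon only, while the counts of hydrogen-bond donors and acceptors stay at 0 and neither group has a net charge. The compounds shown come with no measurement that explains the size of this step.

This single step cannot separate the contribution of the aromatic ring from that of the larger group, and a cyclohexyl ring or a pyridine ring on the same carbon would address that question. Going by these compounds, it also remains open whether phenyl in place of trifluoromethyl gives a similar step on the core of compound 1, which carries a longer chain ending in a carboxylic acid.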